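This account rests on a few compounds, and the source may have more. Where it says the series, first, only, none or still open, it means among the compounds named here.

Three esters sharing one core have been measured in a physicochemical assay for lipophilicity; on this read-out higher numbers stand for higher lipophilicity and lower numbers for lower lipophilicity. Compound 1 `COC(C)(C)CCCC(C)C/C=C/C(C)=C/C(=O)OC(C)(C)C` gives 6.36, compound 2 `C#CCCOC(=O)/C=C(C)/C=C/CC(C)CCCC(C)(C)OC` gives 5.2, and compound 3 `C/C=C/COC(=O)/C=C(C)/C=C/CC(C)CCCC(C)(C)OC` gives 6.07. These numbers place compound 3 in the upper pair of the three. The gap within that pair is a number 0.29 log units lower from compound 1 to compound 3 (within the scatter), while the gap to the remaining number is a number 0.87 log units higher from compound 2 to compound 3 (beyond the scatter).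

The account now turns to compound 4 `COC(C)(C)CCCC(C)C/C=C/C(C)=C/C(=O)OC1CCC1`, which keeps the core and changes only the ester group, with cyclobutyl in place of but-2-en-1-yl on an oxygen next to a carbonyl group. Among the measured compounds shown here, no measured step makes this exchange directly, and no measured compound carries cyclobutyl, so the evidence is indirect.

For the measured compounds named here, two steps bear on it. The exchange leading to compound 3 gave a number 0.29 log units lower from compound 1 to compound 3 (within the scatter), showing that one change of ester group can leave the number within the scatter. The exchange leading to compound 2 gave the large a number 1.16 log units lower from compound 1 to compound 2 (beyond the scatter), but it introduced but-3-yn-1-yl, a group that compound 4 does not carry. A small change is therefore expected in this assay, and the expected step is a number 0.17 log units lower from compound 3 to compound 4 (within the scatter), which is none beyond the scatter. For compound 4 the estimated value is 5.9, with an expected range from 5.4 to 6.4.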

Compound 4, partition coefficient: 6.44
Beside the measured number, compound 4's estimate is 0.54 log units below it; measured number above the stated range.
By their numbers in this assay, from the lowest: compound 2; then compounds 3, 1 and 4 (each within the scatter of the next, the first and the last beyond it).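

In this assay, the exchange of but-2-en-1-yl for cyclobutyl on an oxygen next to a carbonyl group gives a number 0.37 log units higher from compound 3 to compound 4 (beyond the scatter), although each group has 4 carbon atoms, so at this position the way those atoms are joined can alone move the number past the scatter. Two differently shaped groups, cyclobutyl and tert-butyl, now give closely matching numbers, with a number 0.08 log units higher from compound 1 to compound 4 (within the scatter), whereas the exchange from the but-3-yn-1-yl ester gives a number 1.24 log units higher from compound 2 to compound 4 (beyond the scatter), which sets compound 2 clearly apart from compound 4. Nothing available explains why these groups give these numbers.

Because but-2-en-1-yl differs from cyclobutyl both in its double bond and in lacking a ring, the compounds shown cannot separate these two differences, and an open saturated butyl chain on the same oxygen would be needed to tell them apart. From the compounds shown here alone, whether the result extends to a larger carbon ring such as cyclopentyl, or to a four-membered ring containing oxygen such as oxetanyl, also remains open.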